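The source may hold more compounds than are shown below. What is called first, only, known or untested is meant among the compounds shown, and "the series" means these compounds.

Measured so far in an assay on isolated protein for inhibition of aldehyde dehydrogenase 1A1 (Homo sapiens), read by spectrophotometry, tested at 10 uM; on this read-out higher numbers stand for more inhibition at the one concentration tested (going by the name of the read-out) and lower numbers for less inhibition: compound 1 `O=C(C1CC1)N1CCN(Cc2nc3ccccc3n2Cc2ccc(F)cc2)CC1` gives 32.7%; compound 2 `Cc1cccc(Cn2c(CN3CCN(C(=O)c4ccco4)CC3)nc3ccccc32)c1` gives 73.2%; compound 3 `CCCC(=O)N1CCN(Cc2nc3ccccc3n2Cc2cccc(C)c2)CC1` gives 79.1%.

Compound 1 stands lowest of the three, with compound 2 nearest and compound 3 furthest, both beyond the scatter. Within the data shown here, the only single-place step in the set is a number 5.9 percentage points higher from compound 2 to compound 3 (within the scatter), a change at the carbonyl carbon; it does not touch the group that changes here. Compound 4 `O=C(C1CC1)N1CCN(Cc2nc3ccccc3n2Cc2cccc(F)c2)CC1` differs from compound 1 by 3-fluorophenyl in place of 4-fluorophenyl on a saturated chain carbon bound to an aromatic nitrogen. Among the measured compounds shown here, no measured pair shows this change alone, and compounds 2 and 3 differ from compound 1 in more than one place, so no size of step can be read from them. For compound 4 the expected inhibition is 42%, between 18% and 68%. The expected step is a number 9.3 percentage points higher from compound 1 to compound 4 (within the scatter), with no clear direction beyond the scatter.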

Compound 4, a percentage reported as inhibition, at one concentration (the size of the read-out at that concentration, not a potency): 27.2%
For compound 4 the middle estimate is 14.8 percentage points above the measured one; the measured number falls inside the stated range.
By their numbers in this assay, from the lowest: compounds 4 and 1 (each within the scatter of the next); then compounds 2 and 3 (each within the scatter of the next).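

The swap of 4-fluorophenyl for 3-fluorophenyl on a saturated chain carbon bound to an aromatic nitrogen gives a number 5.5 percentage points lower from compound 1 to compound 4 (within the scatter) in this assay. Among these compounds, this is the first single-place reading at this group, and the two fluorophenyl isomers cannot be told apart here. No evidence on why this swap reads as it does is at hand.

Open, as far as these compounds go, is how an unsubstituted benzyl or a benzyl bearing an amine would read at this place. Also open, from the compounds shown here alone, is how 3-methylbenzyl would read alongside the cyclopropyl carbonyl of compound 1.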